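Chloro on compound 1: expected step to compound 4

The compounds below may be only part of what the source reports. "The series", "measured", "known", "first", "only" and "open" are said of these compounds alone.

Values in a functional assay (strain AB) with Danio rerio as the target, read by microscopy, with a stated time of 1 h; a lower number here means that less compound is needed, a higher number that more compound is needed for the effect:
compound 1 `CCN1CCc2c(sc(NC(=O)Nc3ccccc3)c2C(N)=O)C1`: > 25000 nM
compound 2 `CCN1CCc2c(sc(NC(=O)Nc3ccc4ccccc4c3)c2C(N)=O)C1`: 1780 nM
compound 3 `C[N+]1(CC2CCC2)CCc2c(sc(NC(=O)Nc3ccc(Cl)cc3)c2C(N)=O)C1`: 210 nM

Compound 1 gives no number in this assay: its > 25000 nM is a limit. Compound 1 therefore sits at the limit of > 25000 nM in this assay, at which 1 of the 3 values shown sits. Going by the values given here, compound 2 gives 1780 nM and compound 3 gives 210 nM, but neither differs from compound 1 in one place only, so no measured step serves as a direct guide.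

Compound 4 `CCN1CCc2c(sc(NC(=O)Nc3ccc(Cl)cc3)c2C(N)=O)C1` is the next compound to be read. It differs from compound 1 by one change, chloro in place of hydrogen on an aromatic carbon, para to a large group, which turns phenyl into 4-chlorophenyl.

A step beyond the scatter is expected in this assay, towards a lower number, meaning less compound needed for the effect. This expectation rests on compound 3, at 210 nM, which carries the same 4-chlorophenyl group but also differs elsewhere. Its size is uncertain, as the starting point is only a limit and compound 3 is not a close match. The estimated change is an at least 12-fold lower number from compound 1 to compound 4 (1.09 log units; beyond the scatter). For compound 4 the expected value is 2000 nM, with an estimated range of 500 nM to 9000 nM.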

Compound 4, half-maximal effective concentration: 3120 nM
Beside the measured number, compound 4's estimate is 1.6-fold (0.19 log units) below it; measured number inside the range.
By their numbers in this assay, from the lowest: compound 3; then compounds 2 and 4 (each within the scatter of the next). At a limit, above all of these: compound 1.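

In this assay, chloro in place of hydrogen on an aromatic carbon, para to a large group, gives an at least 8.0-fold lower number from compound 1 to compound 4 (0.90 log units; beyond the scatter), so this place on the phenyl group of compound 1 responds to a single added heavy atom. Going by these compounds alone, until now, no two compounds differed in one place only, so this is the first reading that can be tied to one change, phenyl to 4-chlorophenyl, with the rest of the structure held constant. The true size of the step stays open at one end, because the value of compound 1 is a limit and not a number: the limit of > 25000 nM in this assay, at which 1 of the 4 values shown sits.

Whether the gain belongs to chloro in particular remains open, since the compounds shown give no reading for fluoro, bromo, methyl or methoxy at this same place, nor for an amine or a carboxylic acid there. Within the data shown here, also open is whether the same change gives a step of similar size when the ethyl group of compound 1 and compound 4 is replaced by a longer chain, as no such pair is available.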